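Swapping the furan of compound 2 for a tolyl ring

The compounds below may be only part of what the source reports. "The series", "measured", "known", "first", "only" and "open" are said of these compounds alone.

Compound 2 `COc1ccc(CNC(=O)/C(C#N)=C/c2ccc(C)o2)cc1` is the reference point. In a functional assay on DU-145 cells (Homo sapiens) for inhibition, read by MTT assay, with a stated time of 72 h (a higher number here means a weaker inhibitor of growth, a lower number a stronger inhibitor of growth), compound 2 gives 39000 nM. Within the data shown here, only one other number sits beside it: compound 1 `N#C/C(=C\c1ccc(Cl)cc1)C(=O)c1ccc[nH]1` gives 61000 nM in this assay, a difference that lies within the usual scatter, so the two cannot be ranked. Compound 3 `COc1ccc(CNC(=O)/C(C#N)=C/c2ccc(-c3ccccc3)o2)cc1` gives > 100000 nM in this assay, which is a limit of the assay rather than a number. Accordingly the measured step is an at least 2.5-fold higher number from compound 2 to compound 3 (0.40 log units; beyond the scatter), with the phenyl entering in place of the methyl on an aromatic carbon of the furan; that step runs into (the limit of > 100000 nM in this assay, at which 1 of the 3 values shown sits), so its true size is not known.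

Compound 4 `COc1ccc(CNC(=O)/C(C#N)=C/c2ccc(C)cc2)cc1` is not yet measured. It differs from compound 2 by 4-methylphenyl in place of 5-methylfuran-2-yl on a double-bonded chain carbon bound to a double-bonded chain carbon. Among the measured compounds shown here, no measured step touches the ring itself; the one step recorded, the enlargement on the furan that gave an at least 2.5-fold higher number from compound 2 to compound 3 (0.40 log units; beyond the scatter), changes a substituent and does not say how a carbon ring would fare in place of the furan. On that basis compound 4 is expected to stay close to compound 2, with a step of a 1.2-fold higher number from compound 2 to compound 4 (0.06 log units; within the scatter) that is not expected to reach beyond the scatter. The estimate for compound 4 in this assay is therefore 45000 nM, within a range from 15000 nM to 150000 nM.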

Compound 4, concentration for 50% growth inhibition: 34000 nM
For compound 4 the middle estimate is 1.3-fold (0.12 log units) above the measured one; the measured number falls inside the stated range.
By their numbers in this assay, from the lowest: compounds 4, 2 and 1 (each within the scatter of the next). At a limit, above all of these: compound 3.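

In this assay, replacing the ring itself gives a 1.1-fold lower number from compound 2 to compound 4 (0.06 log units; within the scatter), so at this place, on a double-bonded chain carbon bound to a double-bonded chain carbon, 4-methylphenyl and 5-methylfuran-2-yl cannot be told apart. The earlier compounds shown here showed only a change of substituent on the furan, an at least 2.5-fold higher number from compound 2 to compound 3 (0.40 log units; beyond the scatter), which lies beyond the scatter; the new step shows that exchanging the five-membered aromatic ring with its hetero atom for a six-membered aromatic ring of carbon only produces no readable difference, at least for this pair. Nothing given here accounts for this outcome.

Going by these compounds, compound 3 is at a limit of the assay, so the true size of its step remains unknown: the limit of > 100000 nM in this assay, at which 1 of the 4 values shown sits. It also remains open whether the larger substituent would behave in the same way on the carbon ring, and whether an amine or a carboxylic acid in place of the methyl of 4-methylphenyl would move the number in this assay beyond the scatter from compound 4.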